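Swapping a sulfonamide for a furan on a shared core

A few compounds are considered here, and "the series" means these few. Any claim that something is new, unique, unknown or untested is made for them only; others in the source may bear on it.

Measured so far:
compound 1 `CC(=O)Nc1cccc(C(=O)N2CCCC(C(=O)Nc3ccc(Cl)cc3)C2)c1` — 4%
compound 2 `CCN(CC)S(=O)(=O)c1cccc(C(=O)N2CCCC(C(=O)Nc3ccc(Cl)cc3)C2)c1` — 0%

In an ADME assay on PC-3 cells (Homo sapiens) for cytotoxicity, read by WST assay, tested at 100 uM (on this read-out higher numbers stand for more inhibition at the one concentration tested (going by the name of the read-out) and lower numbers for less inhibition), compound 1 gives 4% and compound 2 gives 0%. Compound 2 stands at the lowest of the two numbers, but its nearest neighbour, compound 1, sits only a little higher: the step of a number 4 percentage points lower from compound 1 to compound 2 (within the scatter) is within the scatter, so the two values cannot be ranked against each other.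

Compound 3 `O=C(Nc1ccc(Cl)cc1)C1CCCN(C(=O)c2cccc(-c3ccco3)c2)C1` differs from compound 2 in one place: furan-2-yl in place of diethylsulfamoyl on an aromatic carbon. Going by the values given here, only one measured step bears on this change. It also exchanged the group on an aromatic carbon of the shared core and produced a number 4 percentage points lower from compound 1 to compound 2 (within the scatter), a move that did not leave the scatter. Both measured values lie close to zero, so the evidence available points to a read-out that again stays near the bottom of the scale. The step of a number 4 percentage points higher from compound 2 to compound 3 (within the scatter) is therefore expected to remain within the scatter. For compound 3 the estimate is 4%, with a range from -6% to 16%.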

Compound 3, a percentage reported as inhibition, at one concentration (the size of the read-out at that concentration, not a potency): 0%
Beside the measured number, compound 3's estimate is 4 percentage points above it; the range from low to high includes it.
By their numbers in this assay, from the lowest: compounds 2, 3 and 1 (each within the scatter of the next).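

Replacing diethylsulfamoyl with furan-2-yl on this aromatic carbon in this assay gives no change at the digits printed from compound 2 to compound 3 (within the scatter) and replacing acetamido with furan-2-yl gives a number 4 percentage points lower from compound 1 to compound 3 (within the scatter) so all three groups now tested at this place on the shared core give values within the scatter of one another. The earlier pair compared two groups without a ring, whereas furan-2-yl brings a five-membered aromatic ring and, compared with diethylsulfamoyl, has fewer heavy atoms and fewer hydrogen-bond acceptors. Even these differences in structure give no separation on this read-out, and no measurement offered here explains that result.

The compounds shown leave open whether a simple amine or a carboxylic acid at this aromatic carbon would give a number that stands clear of the scatter. They also leave open whether a change elsewhere on the shared core, rather than at this place, would separate compounds on this read-out.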